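Notes on the aryl swap from compound 3 to compound 4

A few compounds are considered here, and "the series" means these few. Any claim that something is new, unique, unknown or untested is made for them only; others in the source may bear on it.

Compound 1 `COc1cc(-c2ncnn2-c2cccc(N)c2)cc(OC)c1OC` in a functional assay on MCF7 cells (Homo sapiens) for antiproliferative activity, read by MTT assay, with a stated time of 72 h (on this read-out higher numbers stand for weaker inhibition and lower numbers for stronger inhibition), gives > 10000 nM; this is a limit of the assay.
Compound 2 `COc1cc(-c2ncnn2-c2ccccc2)cc(OC)c1OC` in this assay gives > 10000 nM; this too is a limit of the assay.
Compound 3 `COc1ccc(-n2ncnc2-c2cc(OC)c(OC)c(OC)c2)cc1` in this assay gives 7400 nM.

Going by the values given here, compound 3 holds the only number in this assay; the other two values are limits, as noted in the limit of > 10000 nM in this assay, at which 2 of the 3 values shown sit. The step that the two limits leave unreadable from compound 1 to compound 2 is therefore unreadable. The steps of an at least 1.3-fold lower number from compound 1 to compound 3 (0.13 log units; that floor lies within the scatter) and an at least 1.3-fold lower number from compound 2 to compound 3 (0.13 log units; that floor lies within the scatter) have readable floors only, and those floors sit within the scatter, so no order between compound 3 and compound 1 or compound 2 is established.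

Compound 4 `COc1cc(-c2ncnn2-c2ccc(Cl)c(Cl)c2)cc(OC)c1OC` differs from compound 3 by 3,4-dichlorophenyl in place of 4-methoxyphenyl on an aromatic nitrogen. Among the compounds with values here, no measured step exchanges the 4-methoxyphenyl for a 3,4-dichlorophenyl; the only steps that touch the group on the aromatic nitrogen are those from compound 1 and compound 2 to compound 3, and their floors lie within the scatter. The expectation for compound 4 therefore rests on compound 3 staying near its own value, with a wide range that reaches the limit. Compound 4 is expected at 6000 nM, between 2000 nM and 20000 nM. The expected step of a 1.2-fold lower number from compound 3 to compound 4 (0.09 log units; within the scatter) is no change beyond the scatter.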

Compound 4, half-maximal inhibitory concentration: > 10000 nM
Compound 4 was reported as a limit (the forecaster's own chance of this, stated with the estimate: 35%); middle value at least 1.6-fold (0.22 log units) from the limit.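

Going by these compounds alone, on the aromatic nitrogen, 3,4-dichlorophenyl now joins phenyl and 3-aminophenyl at the limit of the assay, which leaves compound 3, with its 4-methoxyphenyl, as the only compound with a number in this assay. Within the data shown here, the one readable new step is an at least 1.3-fold higher number from compound 3 to compound 4 (0.13 log units; that floor lies within the scatter), so this swap does not separate the two compounds, and the steps to compound 4 from the other two compounds held at the limit cannot be read. The series therefore offers no ranking of the groups at this position, and the data stop at one ceiling: the limit of > 10000 nM in this assay, at which 3 of the 4 values shown sit.

From the compounds shown here alone, how far compound 1, compound 2 and compound 4 lie beyond that limit stays open, so any difference among the phenyl, 3-aminophenyl and 3,4-dichlorophenyl groups remains hidden. Also open, going by these compounds, is whether a phenyl carrying a carboxylic acid, a nitrile or a longer alkoxy chain on this aromatic nitrogen would give a number that stands clear of the scatter around compound 3.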